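Removing the Methoxy Group: From Compound 3 to Compound 4

This account rests on a few compounds, and the source may have more. Where it says the series, first, only, none or still open, it means among the compounds named here.

Compound 3 `COc1ccc(/C=N/NC(=S)Nc2nc3ccc(Cl)cc3s2)cc1` gives 300 mg/kg in a functional assay on the whole organism with Mus musculus as the target, in the maximal electroshock model, with a stated time of 4 h; on this read-out higher numbers stand for an effect only at larger amounts of compound and lower numbers for an effect already at smaller amounts. On that number compound 3 stands level with compound 2 `O=C(Cn1ccc2ccccc21)Nc1nc2ccc(Cl)cc2s1`, which gives 300 mg/kg, the two together holding the highest number of the three measured; compound 1 `Fc1ccc(/C=N/NC(=S)Nc2nc3ccc(Cl)cc3s2)cc1` gives 30 mg/kg and is the furthest from compound 3. Among the measured compounds shown here, the only measured change on the shared core is a 10-fold higher number from compound 1 to compound 3 (1.00 log units; beyond the scatter). Compound 4 `S=C(N/N=C/c1ccccc1)Nc1nc2ccc(Cl)cc2s1` has not yet been measured and differs from compound 3 by hydrogen in place of methoxy on an aromatic carbon. For the measured compounds named here, no measured step exchanges methoxy for hydrogen, so the step from compound 1 to compound 3 is the nearest guide: it shows the number rising when methoxy replaces a fluoro at that carbon. Since compound 1 gives 30 mg/kg with a fluoro in that place, compound 4 is expected to move toward it, by an estimated 3.0-fold lower number from compound 3 to compound 4 (0.48 log units; beyond the scatter). Compound 4 is accordingly estimated at 100 mg/kg, within a range from 30 mg/kg to 300 mg/kg.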

Compound 4, minimum effective dose in the Mus musculus assay: 300 mg/kg
Compound 4: middle estimate off by 3.0-fold (0.48 log units), on the low side; the range from low to high includes it.
By their numbers in the Mus musculus assay, from the lowest: compound 1; then compounds 2, 3 and 4 (each within the scatter of the next).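

In the Mus musculus assay, taking the methoxy group off this carbon leaves the number where it stood, with no change at the digits printed from compound 3 to compound 4 (within the scatter), so the 4-methoxyphenyl group and the plain phenyl group cannot be told apart here. In the Mus musculus assay, the change from fluoro to hydrogen gives a 10-fold higher number from compound 1 to compound 4 (1.00 log units; beyond the scatter), which matches the earlier step from fluoro to methoxy, and among these three groups on this carbon only fluoro goes with the lower number. In a physicochemical assay for lipophilicity, in phosphate buffer, measured as octanol-water partition (a higher number here means a more lipophilic compound, a lower number a more polar compound), compound 3 gives 5.16 and compound 4 gives 4.86, values within the scatter of each other.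

Nothing at hand accounts for what sets the fluoro compound apart. On these data alone, whether a chloro group, an amine or a longer chain such as ethoxy on this carbon would side with compound 1 or with compounds 3 and 4 stays open.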